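The source may report more compounds than this note shows. Statements on the series, on what has been measured and on what is new or still open speak of the compounds shown alone.

In an ADME assay on HEK293 cells (Homo sapiens) for cytotoxicity, read by resazurin assay, with a stated time of 48 h (on this read-out higher numbers stand for lower toxicity in this test and lower numbers for higher toxicity in this test), compound 1 `O=S(=O)(Nc1ccc2oc(-c3ccccc3)nc2c1)c1cccc(C(F)(F)F)c1` gives > 100000 nM as a limit and not a number. Compound 2 `O=S(=O)(Nc1ccc2oc(-c3ccccc3)nc2c1)c1ccc(F)c(C(F)(F)F)c1` gives > 100000 nM as a limit too. Among the measured compounds shown here, the one measured step that bears on this is a step that the two limits leave unreadable from compound 1 to compound 2 and it offers no size to carry over. For the measured compounds named here, both compounds share the limit of > 100000 nM in this assay, at which 2 of the 2 values shown sit, as their only guide. Compound 3 `COc1cccc(S(=O)(=O)Nc2ccc3oc(-c4ccccc4)nc3c2)c1` has methoxy in place of trifluoromethyl on an aromatic carbon. The estimated step is a number no higher from compound 1 to compound 3 (the limit leaves the size open) and no change beyond the usual scatter is expected in this assay here. For compound 3 the expected value is 100000 nM with an estimated range from 40000 nM to 100000 nM as its ends.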

Compound 3, half-maximal cytotoxic concentration: 63000 nM
For compound 3 the middle estimate is 1.6-fold (0.20 log units) above the measured one; low and high end bracket the measured number.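

With methoxy in place of trifluoromethyl, this position yields the first actual number in this assay, rather than another limit: the limit of > 100000 nM in this assay, at which 2 of the 3 values shown sit.

The change gives an at least 1.5-fold lower number from compound 1 to compound 3 (0.20 log units; that floor lies within the scatter). Since compound 1 has only a limit, this is a floor and the true size of the step may be larger, so even a small change at this ring position can bring the read-out within measurable range.

On these data alone, it remains open how an amine, a carboxylic acid or a longer chain such as ethoxy at this position would read in this assay. As far as these compounds go, whether fluoro, as in compound 2, would alter the value of compound 3 also remains open.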